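Cyano in place of trifluoromethyl: two positions compared

The source may hold more compounds than are shown below. What is called first, only, known or untested is meant among the compounds shown, and "the series" means these compounds.

Measured compounds:
- compound 1 `CC(=O)/C(=N\c1cccc(C#N)c1)NNc1ccccc1C`; in an assay on isolated protein for binding affinity to corticotropin-releasing factor receptor 1 (Homo sapiens) (on this read-out lower numbers stand for stronger inhibition and higher numbers for weaker inhibition), compound 1 reports only a limit, > 10000 nM.
- compound 2 `CC(=O)/C(=N\c1cccc(C(F)(F)F)c1)NNc1ccccc1C`; in this assay compound 2 gives 291 nM.
- compound 3 `CC(=O)/C(=N\c1ccccc1)NNc1ccccc1C(F)(F)F`; in this assay compound 3 gives 2260 nM.

Within this assay compound 3 stands highest, and the difference between its core and the core of compound 2 is not broken down here. The change cyano in place of trifluoromethyl on an aromatic carbon gave an at least 34-fold higher number from compound 2 to compound 1 (1.53 log units; beyond the scatter), the value of compound 1 being a limit (the limit of > 10000 nM in this assay, at which 1 of the 3 values shown sits).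

Compound 4 `CC(=O)/C(=N\c1ccccc1)NNc1ccccc1C#N` is not yet measured. It is the same kind of change as before, (cyano in place of trifluoromethyl on an aromatic carbon), but here ortho to a large group rather than meta to a large group. For compound 4 a step of a 13-fold higher number from compound 3 to compound 4 (1.12 log units; beyond the scatter) is expected, resting on compound 3 at 2260 nM and on the step of an at least 34-fold higher number from compound 2 to compound 1 (1.53 log units; beyond the scatter). Compound 4 is estimated at 30000 nM, between 8000 nM and 150000 nM, most likely reported only as a limit.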

Compound 4, inhibition constant: 1080 nM
The estimate for compound 4 lay 28-fold (1.44 log units) above the measured number, outside the stated range (below it).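

On the core of compound 3, cyano in place of trifluoromethyl gave a 2.1-fold lower number from compound 3 to compound 4 (0.32 log units; beyond the scatter), so the result on one core does not predict the result on the other in this assay: the same change on two cores in this assay, an at least 34-fold higher number (1.53 log units; beyond the scatter) from compound 2 to compound 1 and a 2.1-fold lower number (0.32 log units; beyond the scatter) from compound 3 to compound 4, at least 71-fold (1.85 log units) apart, beyond the scatter of two such steps

Compound 1 reports only a limit, so the full size of its step stays unknown: the limit of > 10000 nM in this assay, at which 1 of the 4 values shown sits.

With a single pair on each core, the data do not show which difference between the cores goes with this reversal.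

Still open, going by these compounds, is how a chlorine atom or a methoxy group in place of trifluoromethyl would behave on either core. Also open, on these data alone, is whether an amine or a carboxylic acid there would follow the pattern of either pair.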